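Series notes: cyano-cycloalkyl amides of a morpholine succinamide

A few compounds are considered here, and "the series" means these few. Any claim that something is new, unique, unknown or untested is made for them only; others in the source may bear on it.

Measured so far:
compound 1, `N#CC1(NC(=O)[C@@H](CC(=O)N2CCOCC2)CC2CCCCC2)CC1`, 135 nM
compound 2, `N#C[C@@]1(NC(=O)[C@@H](CC(=O)N2CCOCC2)CC2CCCCC2)CCNC1`, 141 nM

In an assay on isolated protein for inhibition of cathepsin S (Homo sapiens) (a higher number here means a weaker inhibitor, a lower number a stronger inhibitor), compound 1 gives 135 nM and compound 2 gives 141 nM. Of the two numbers compound 2 carries the larger one, but the gap between compound 2 and compound 1 lies within the scatter, so the two are not told apart by this assay.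

Compound 3, `CN1CCC(C#N)(NC(=O)[C@@H](CC(=O)N2CCOCC2)CC2CCCCC2)CC1`, is not yet measured. It differs from compound 2 in one place: 4-cyano-1-methylpiperidin-4-yl in place of 3-cyanopyrrolidin-3-yl on an amide-type nitrogen.

Going by the values given here, the only measured step that bears on the cyano-substituted ring on the amide-type nitrogen is a 1.0-fold higher number from compound 1 to compound 2 (0.02 log units; within the scatter), which was flat. That step covered a change from a carbocycle to a ring with one hetero atom, and this assay did not move. The change to compound 3 widens the ring and replaces the donor with a methyl group; nothing measured speaks to either part. The expectation is therefore a step of a 1.2-fold higher number from compound 2 to compound 3 (0.08 log units; within the scatter) in this assay, most likely within the scatter, in no firm direction. Compound 3 is estimated at 170 nM, within a range of 60 nM to 480 nM.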

Compound 3, half-maximal inhibitory concentration: 251 nM
Compound 3: the middle estimate sits 1.5-fold (0.17 log units) below what was measured; the range from low to high includes it.
By their numbers in this assay, from the lowest: compounds 1, 2 and 3 (each within the scatter of the next).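

In this assay the move to 4-cyano-1-methylpiperidin-4-yl on the amide-type nitrogen gives a 1.8-fold higher number from compound 2 to compound 3 (0.25 log units; within the scatter) and also a 1.9-fold higher number from compound 1 to compound 3 (0.27 log units; within the scatter) so neither step separates compound 3 from its neighbours. The position therefore accepts a six-membered ring with a methyl group and 0 hydrogen-bond donors, as well as the 3-cyanopyrrolidin-3-yl and 1-cyanocyclopropyl groups, with all of these steps within the scatter. No supporting measurement bears on this result.

From the compounds shown here alone, the step from compound 2 to compound 3 changes ring size and the group on the ring nitrogen together, so the contribution of each remains open. A 4-cyanopiperidin-4-yl group with a free ring amine, or a 3-cyanopyrrolidin-3-yl group carrying a methyl on its ring nitrogen, would address these two parts singly.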